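The compounds below may be only part of what the source reports. "The series", "measured", "known", "first", "only" and "open" are said of these compounds alone.

Measured in a functional assay on HOS-TE85 cells (Homo sapiens) for inhibition, read by CCK-8 assay, with a stated time of 72 h; on this read-out higher numbers stand for weaker inhibition and lower numbers for stronger inhibition:

Compound 1, `COc1ccccc1N1C(=O)CSC1c1cccc(C(=O)NCCCCn2cccn2)c1`: 91.7 nM
Compound 2, `O=C(NCCCCc1ccccc1)c1cccc(C2SCC(=O)N2c2cccc(F)c2)c1`: 32.4 nM

Of these two, compound 2 stands with the lower number, and compound 1 lies above it by a gap beyond the scatter. Compound 3, `O=C(NCCCCc1ccccc1)c1cccc(C2SCC(=O)N2c2cnccn2)c1`, differs from compound 2 in one place: pyrazin-2-yl in place of 3-fluorophenyl on an amide-type nitrogen in a ring. Among the compounds with values here, no measured pair shows this change, so the direction is open; a small step, at most around the edge of the scatter and more likely toward a higher number, is expected as a 1.9-fold higher number from compound 2 to compound 3 (0.27 log units; within the scatter). Compound 3 is thus estimated at 60 nM, with a range from 15 nM to 250 nM.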

Compound 3, half-maximal inhibitory concentration: > 1000 nM
Compound 3 ended at the assay's limit (the forecaster's own chance of this, stated with the estimate: 5%); middle value at least 16-fold (1.22 log units) from the limit.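

In this assay, the group on the amide-type nitrogen in the ring proved far from interchangeable: pyrazin-2-yl in place of 3-fluorophenyl gives an at least 30-fold higher number from compound 2 to compound 3 (1.48 log units; beyond the scatter). This position therefore does not accept every six-membered aromatic ring alike, and swapping a carbon-only ring for one with two ring nitrogens can cost nearly all measurable inhibition here. The value of compound 3 is a limit and not a number: the limit of > 1000 nM in this assay, at which 1 of the 3 values shown sits.

The compounds shown leave open whether a plain phenyl or a pyridin-2-yl group on this nitrogen would stay near compound 2 or fall with compound 3.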